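Working notes on compounds 1 to 4

The compounds below may be only part of what the source reports. "The series", "measured", "known", "first", "only" and "open" are said of these compounds alone.

Measured so far:
compound 1, `CC(C)(C)c1ccc(NC(=O)c2ccc(-c3ccccn3)cc2)cc1`, 8 nM
compound 2, `CC(C)(C)c1ccc(NC(=O)c2ccc(-c3ncccc3F)cc2)cc1`, 1 nM
compound 3, `CC(C)(C)c1ccc(NC(=O)c2ccc(-c3ncccc3NS(C)(=O)=O)cc2)cc1`, 35 nM

In a functional assay for antagonist activity at transient receptor potential cation channel subfamily V member 1 (Rattus norvegicus) (a higher number here means a weaker inhibitor, a lower number a stronger inhibitor), compound 3 stands highest of the three numbers; the nearest is compound 1, as seen in a 4.4-fold higher number from compound 1 to compound 3 (0.64 log units; beyond the scatter), and the furthest is compound 2, as seen in a 35-fold higher number from compound 2 to compound 3 (1.54 log units; beyond the scatter).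

Compound 4, `CN(C)Cc1cccnc1-c1ccc(C(=O)Nc2ccc(C(C)(C)C)cc2)cc1`, has not yet been measured. It differs from compound 3 by (dimethylamino)methyl in place of methanesulfonamido on an aromatic carbon.

Both measured steps that bear on this position are relevant. Adding methanesulfonamido gave a 4.4-fold higher number from compound 1 to compound 3 (0.64 log units; beyond the scatter), and exchanging fluoro for it gave a 35-fold higher number from compound 2 to compound 3 (1.54 log units; beyond the scatter). For the measured compounds named here, compound 4 removes the methanesulfonamido group, so the number is expected to fall, but no measured step shows a (dimethylamino)methyl group at this place, so the size is uncertain. Compound 4 is expected to give a step of a 3.5-fold lower number from compound 3 to compound 4 (0.54 log units; beyond the scatter) in this assay. The estimate for compound 4 is 10 nM, with a range from 2 nM to 60 nM.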

Compound 4, half-maximal inhibitory concentration: 234 nM
Estimate against measurement, compound 4: 23-fold (1.37 log units) below; measured number outside the range, above it.
By their numbers in this assay, from the lowest: compound 2; then compound 1; then compound 3; then compound 4.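

In this assay, (dimethylamino)methyl on this aromatic carbon gives a 6.7-fold higher number from compound 3 to compound 4 (0.83 log units; beyond the scatter) and so ranks below methanesulfonamido, the poorest group at this place until now. Against the smaller groups it gives a 29-fold higher number from compound 1 to compound 4 (1.47 log units; beyond the scatter) and a 230-fold higher number from compound 2 to compound 4 (2.37 log units; beyond the scatter), which extends the order at this place to fluoro, hydrogen, methanesulfonamido and (dimethylamino)methyl, with each group giving a higher number than the one before it. No measured evidence accounts for this order.

As far as these compounds go, whether methyl, chloro or hydroxymethyl would stay near compound 2 or compound 1 remains open. So does whether a primary amine on the same carbon would match compound 4.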